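This account rests on a few compounds, and the source may have more. Where it says the series, first, only, none or still open, it means among the compounds named here.

Measured in a functional assay on MDA-MB-231 cells (Homo sapiens) for antiproliferative activity, read by MTT assay, with a stated time of 48 h; on this read-out higher numbers stand for weaker inhibition and lower numbers for stronger inhibition:
- Compound 1 `Cc1c(Cc2ccccc2)c(=O)oc2cc(OCCOc3no[n+]([O-])c3S(=O)(=O)c3ccccc3)ccc12`: 6 nM
- Compound 2 `COc1cc(OCCOc2no[n+]([O-])c2S(=O)(=O)c2ccccc2)ccc1C(=O)/C=C/c1ccc(F)cc1`: 1.4 nM

Of these two, compound 2 holds the lower number, 1.4 nM, and so shows the stronger inhibition. Compound 1 stands at 6 nM, and the gap between the two lies beyond the scatter.

Compound 3 `COc1cc(OCCOc2no[n+]([O-])c2S(=O)(=O)c2ccccc2)ccc1C(=O)/C=C/c1ccccc1` has not yet been measured. It departs from compound 2 in one place: hydrogen in place of fluoro on an aromatic carbon. This puts hydrogen in place of fluoro on an aromatic carbon, para to a large group, turning the 4-fluorophenyl into a phenyl and leaving the rest of the structure unchanged.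

Among the compounds with values here, no measured pair in this small set shows what such a change does, so the expectation rests on compound 2 at 1.4 nM and on how small the change is. In this assay, the expected result is a small rise in the number, with no step beyond the scatter, and the estimated size is a 1.6-fold higher number from compound 2 to compound 3 (0.20 log units; within the scatter). For compound 3 the estimated value is 2.2 nM, with an expected range of 0.7 nM to 7 nM.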

Compound 3, half-maximal inhibitory concentration: 0.5 nM
The estimate for compound 3 lay 4.4-fold (0.64 log units) above the measured number; measured number outside the range, below it.
By their numbers in this assay, from the lowest: compound 3; then compound 2; then compound 1.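

In this assay, within the data shown here, hydrogen in place of fluoro gives a 2.8-fold lower number from compound 2 to compound 3 (0.45 log units; beyond the scatter), the first change in this set that can be read at a single place. It shows that fluoro on this aromatic carbon, para to a large group, is not needed for a low number here: the plain phenyl of compound 3 gives a lower number than the 4-fluorophenyl of compound 2, and the step lies beyond the scatter. No measurement shown here bears on why the number falls.

The compounds shown leave open whether other groups at this place, such as chloro, methoxy or an amine, would give a lower or a higher number than hydrogen, as this single pair offers only fluoro and hydrogen for comparison. On these data alone, it also remains open whether the same exchange would move the number in the same direction elsewhere, for instance with fluoro placed on the phenyl group of compound 1, or on the phenyl of the sulfonyl group that all three compounds share.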